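The compounds below may be only part of what the source reports. "The series", "measured", "known", "first", "only" and "open" are said of these compounds alone.

Cytotoxicity across the series is read in an ADME assay on L6 cells (Rattus norvegicus) for cytotoxicity, read by fluorescence and resazurin assay, with a stated time of 72 h; on this read-out lower numbers stand for an effect already at smaller amounts and higher numbers for an effect only at larger amounts of compound. Compound 1 `Cc1cc(-c2ccc3[nH]c(=O)nc(-c4ccccc4)c3c2)ccn1` gives in this assay only the limit > 50000 nM. Compound 2 `N#Cc1ccc(-c2ccc3[nH]c(=O)nc(-c4ccccc4)c3c2)cc1` gives only the limit > 50000 nM. Compound 3 `O=c1nc(-c2ccccc2)c2cc(-c3cn[nH]c3)ccc2[nH]1` likewise gives only the limit > 50000 nM. The steps a step that the two limits leave unreadable from compound 1 to compound 2, a step that the two limits leave unreadable from compound 1 to compound 3 and a step that the two limits leave unreadable from compound 2 to compound 3 therefore carry no readable size, since (the limit of > 50000 nM in this assay, at which 3 of the 3 values shown sit). Compound 4 `Cn1cc(-c2ccc3[nH]c(=O)nc(-c4ccccc4)c3c2)cn1` differs from compound 3 by methyl in place of hydrogen on an aromatic nitrogen. Among the compounds with values here, no measured step bears on this change with a readable size; the three unreadable steps show only that varying the group on an aromatic carbon has left every compound at the limit. The step from compound 3 to compound 4 is expected to be a step that the limit leaves unreadable from compound 3 to compound 4, that is none beyond the scatter. For compound 4 the estimate is 80000 nM, with a range from 40000 nM to 200000 nM, most likely again reported as a limit.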

Compound 4, half-maximal effective concentration: > 50000 nM
Compound 4 gave a limit, no number; the forecaster's own chance of this, stated with the estimate: 90%; the middle value does not contradict the limit.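

Within the data shown here, no step from compound 1, compound 2 or compound 3 to compound 4 can be read, and the series stays unresolved: the limit of > 50000 nM in this assay, at which 4 of the 4 values shown sit. The compounds shown leave open whether any change on the shared core would give a number rather than a limit.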